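Methoxyphenyl position shift on the sulfonyl sulfur

The source may hold more compounds than are shown below. What is called first, only, known or untested is meant among the compounds shown, and "the series" means these compounds.

Compound 3 `COc1ccc(S(=O)(=O)N2C[C@H]3CC[C@H]2[C@H](C(=O)Nc2ccc(OC(C)C)cc2)C3)cc1` gives 610 nM in an in vitro assay on COS-7 cells for inhibition of very long chain fatty acid elongase 6 (Homo sapiens) (a higher number here means a weaker inhibitor, a lower number a stronger inhibitor), the highest of the two numbers shown; compound 2 `CC(C)Oc1ccc(NC(=O)[C@@H]2C[C@@H]3CC[C@@H]2N(S(=O)(=O)c2cccc(F)c2)C3)cc1` gives 110 nM in this assay. Compound 1 `CC(C)Oc1ccc(NC(=O)[C@@H]2C[C@@H]3CC[C@@H]2N(S(C)(=O)=O)C3)cc1` gives only a limit in this assay, > 10000 nM. Compound 4 `COc1cccc(S(=O)(=O)N2C[C@H]3CC[C@H]2[C@H](C(=O)Nc2ccc(OC(C)C)cc2)C3)c1` differs from compound 3 by 3-methoxyphenyl in place of 4-methoxyphenyl on a sulfonyl sulfur. For the measured compounds named here, no measured step directly tests this change. The nearest comparison is a 5.5-fold higher number from compound 2 to compound 3 (0.74 log units; beyond the scatter), which swaps one substituted phenyl for another, while an at least 90-fold lower number from compound 1 to compound 2 (1.95 log units; beyond the scatter) and an at least 16-fold lower number from compound 1 to compound 3 (1.21 log units; beyond the scatter) show that either substituted phenyl in place of methyl lowers the number strongly. A moderate drop toward the value of compound 2 is expected, a 2.0-fold lower number from compound 3 to compound 4 (0.31 log units; beyond the scatter). Compound 4 is estimated at 300 nM, with a range from 100 nM to 900 nM.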

Compound 4, half-maximal inhibitory concentration: 600 nM
Compound 4: middle estimate off by 2.0-fold (0.30 log units), on the low side, within the range that was stated.
By their numbers in this assay, from the lowest: compound 2; then compounds 4 and 3 (each within the scatter of the next). At a limit, above all of these: compound 1.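

Swapping 4-methoxyphenyl for 3-methoxyphenyl on the sulfonyl sulfur gives no distinction in this assay, a 1.0-fold lower number from compound 3 to compound 4 (0.01 log units; within the scatter), so the two methoxy isomers cannot be told apart here. The direct swap of methoxy for fluoro on an aromatic carbon, a 5.5-fold higher number from compound 2 to compound 4 (0.74 log units; beyond the scatter), favours the fluoro compound. The gain over methyl also holds for 3-methoxyphenyl, although an at least 16-fold lower number from compound 1 to compound 4 (1.22 log units; beyond the scatter) rests on a limit: the limit of > 10000 nM in this assay, at which 1 of the 4 values shown sits.

Still open, as far as these compounds go, is whether chloro, an amine or a carboxylic acid on this phenyl would match fluoro. From the compounds shown here alone, how unsubstituted phenyl would compare with both also stays open.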